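Amide variation on the carbonyl: outlook for compound 4

The source may hold more compounds than are shown below. What is called first, only, known or untested is meant among the compounds shown, and "the series" means these compounds.

In a functional assay on the whole organism for inhibition, with Rattus norvegicus as the target, read by paw edema, at a dose of 100 mg/kg by the oral route (a higher number here means more inhibition at the dose given (going by the name of the read-out), a lower number less inhibition), compound 1 `CCOC(=O)c1c(O)c2cccnc2n(-c2ccccc2)c1=O` gives 23.5%, compound 2 `O=C(NCc1ccccc1)c1c(O)c2cccnc2n(-c2ccccc2)c1=O` gives 1.6% and compound 3 `O=C(Nc1cnccn1)c1c(O)c2cccnc2n(-c2ccccc2)c1=O` gives 29.6%. Compound 3 carries the largest of the three numbers; the gap from compound 1 is a number 6.1 percentage points higher from compound 1 to compound 3 (within the scatter), while the gap from compound 2 is a number 28 percentage points higher from compound 2 to compound 3 (beyond the scatter). Compound 4 `O=C(NCc1ccncc1)c1c(O)c2cccnc2n(-c2ccccc2)c1=O` differs from compound 3 by (pyridin-4-yl)methyl in place of pyrazin-2-yl on an amide-type nitrogen. One measured step that bears on this is a number 21.9 percentage points lower from compound 1 to compound 2 (beyond the scatter). The other is the step from compound 2 to compound 3 already given. Both place the benzyl amide at the low end, and a (pyridin-4-yl)methyl amide resembles that case more closely than the pyrazin-2-yl one, so a fall beyond the scatter is expected, a number 20.6 percentage points lower from compound 3 to compound 4 (beyond the scatter). Compound 4 is therefore estimated at 9%, within 0% to 24%.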

Compound 4, a percentage reported as inhibition, in the whole organism at one dose (the size of the read-out at that dose, not a potency): 10%
Compound 4: the middle estimate sits 1 percentage points below what was measured; low and high end bracket the measured number.
By their numbers in this assay, from the lowest: compounds 2 and 4 (each within the scatter of the next); then compounds 1 and 3 (each within the scatter of the next).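

In this assay the ((pyridin-4-yl)methyl)amino amide stands with the benzylamino amide, not the (pyrazin-2-yl)amino amide: pyridin-4-yl in place of phenyl gives a number 8.4 percentage points higher from compound 2 to compound 4 (within the scatter), whereas the change on the amide-type nitrogen gives a number 19.6 percentage points lower from compound 3 to compound 4 (beyond the scatter). Replacing ethoxy on the carbonyl carbon gives a number 13.5 percentage points lower from compound 1 to compound 4 (beyond the scatter), so both amides with a saturated chain carbon on the nitrogen lie below the ethoxy compound by more than the scatter. Nothing available explains this difference.

Open, as far as these compounds go, is whether a 2-(pyridin-4-yl)ethyl group on the amide-type nitrogen would stand with compound 2 and compound 4 or with compound 3.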